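The source may report more compounds than this note shows. Statements on the series, on what has been measured and on what is new or still open speak of the compounds shown alone.

Measured so far in a functional assay on the whole organism (strain Swiss) with Mus musculus as the target, in the maximal electroshock model, with a stated time of 0.25 h, at a dose of 300 mg/kg by the intraperitoneal route; a lower number here means a weaker effect, a higher number a stronger effect of the compound at the dose given:

compound 1, `CC(C(=O)N1CCN(c2ccc(Cl)cc2)CC1)N1C(=O)CCC1=O`: 100%
compound 2, `CC(C(=O)N1CCN(c2ccccc2Cl)CC1)N1C(=O)CCC1=O`: 0%

Compound 2 stands lowest of the two numbers shown; the nearest is compound 1, and the step from 2-chlorophenyl to 4-chlorophenyl is a number 100 percentage points lower from compound 1 to compound 2 (beyond the scatter), a large drop reached in one change on the amine nitrogen in the ring.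

Compound 3, `Cc1cccc(N2CCN(C(=O)C(C)N3C(=O)CCC3=O)CC2)c1`, is not yet measured. It differs from compound 2 by 3-methylphenyl in place of 2-chlorophenyl on an amine nitrogen in a ring. Going by the values given here, only the step from compound 1 to compound 2 bears on this, and only in part: it shows that the 2-chlorophenyl group on that nitrogen sits at the bottom of the series, while 4-chlorophenyl sits at the top. Among the compounds with values here, no measured compound carries 3-methylphenyl, so the direction rests on leaving 2-chlorophenyl alone. A step upward in this assay is expected, of the size a number 60 percentage points higher from compound 2 to compound 3 (beyond the scatter), though with wide uncertainty. Compound 3 is estimated at 60%, within 10% to 100%.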

Compound 3, a percentage reported as activity, at one dose (the size of the read-out at that dose, not a potency): 100%
The estimate for compound 3 lay 40 percentage points below the measured number, and the stated range covers the measured number.
By their numbers in this assay, from the lowest: compound 2; then compounds 1 and 3 (each within the scatter of the next).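

In this assay, replacing 2-chlorophenyl with 3-methylphenyl gives a number 100 percentage points higher from compound 2 to compound 3 (beyond the scatter), so the loss seen with 2-chlorophenyl on this amine nitrogen is not common to every substituted phenyl group. Replacing 4-chlorophenyl with 3-methylphenyl gives no change at the digits printed from compound 1 to compound 3 (within the scatter), so chlorine on the phenyl group is not required for the full read-out, and of the three groups only 2-chlorophenyl stands apart. No measurement available here explains the difference between these groups.

The compounds shown do not separate the placement of the group on the phenyl ring from the identity of the group: 2-methylphenyl and 3-chlorophenyl would address that. As far as these compounds go, whether compound 1 and compound 3 remain alike at a lower dose or a later time also stays open.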